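Three Analogues at the Assay Limit and a Fourth

A few compounds are considered here, and "the series" means these few. Any claim that something is new, unique, unknown or untested is made for them only; others in the source may bear on it.

Compound 1 `COc1cc(-c2nnc(SCC(=O)c3ccc(Cl)cc3)n2N)cc(OC)c1OC`, compound 2 `COc1cc(-c2nnc(SCC(=O)c3ccc(C)cc3)n2N)cc(OC)c1OC` and compound 3 `COc1cc(-c2nnc(SCC(=O)NCc3ccc(Cl)cc3)n2N)cc(OC)c1OC` share one core. In a functional assay on HepG2 cells (Homo sapiens) for antiproliferative activity, read by MTT assay, with a stated time of 48 h (a lower number here means a stronger inhibitor, a higher number a weaker inhibitor), compound 1 gives only a limit, > 100000 nM. Compound 2 likewise gives only a limit in this assay, > 100000 nM. Compound 3 also gives only a limit, > 100000 nM. The change methyl in place of chloro on an aromatic carbon produces a step that the two limits leave unreadable from compound 1 to compound 2, and the core change (4-chlorobenzyl)amino in place of 4-chlorophenyl on a carbonyl carbon produces a step that the two limits leave unreadable from compound 1 to compound 3; the pair also shows a step that the two limits leave unreadable from compound 2 to compound 3. All of this rests on (the limit of > 100000 nM in this assay, at which 3 of the 3 values shown sit).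

Compound 4 `COc1cc(-c2nnc(SCC(=O)NCc3ccc(C)cc3)n2N)cc(OC)c1OC` differs from compound 3 by methyl in place of chloro on an aromatic carbon, the same change as from compound 1 to compound 2, at the same place. Because compound 3 gives > 100000 nM, compound 4 is expected to remain at the limit, an expected step of a number no higher from compound 3 to compound 4 (the limit leaves the size open) and an expected value of 100000 nM.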

Compound 4, half-maximal inhibitory concentration: > 100000 nM
Compound 4: a limit, no number (the forecaster's own chance of this, stated with the estimate: 85%); the middle value sits exactly at the limit.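

No step can be read between compound 1, compound 2, compound 3 and compound 4, since each gives only a limit and no number: the limit of > 100000 nM in this assay, at which 4 of the 4 values shown sit.

The compounds shown leave open what either change does to activity in this assay.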